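Permeability of three measured compounds and one estimate

A few compounds are considered here, and "the series" means these few. Any claim that something is new, unique, unknown or untested is made for them only; others in the source may bear on it.

Measured so far:
compound 1, `Oc1ccc(-c2cc3ccccc3o2)c2cccnc12`, 4.3 10^-6 cm/s
compound 2, `Oc1ccc(-c2cc3cccc(O)c3o2)c2cccnc12`, 14.5 10^-6 cm/s
compound 3, `Oc1c(Cl)cc(-c2cc3ccccc3o2)c2cccnc12`, 2.6 10^-6 cm/s

All three were run in an ADME assay for permeability, using PAMPA, with a stated time of 10 h, tested at 100 ug/mL; a lower number here means that the compound crosses the layer more slowly, a higher number that the compound crosses the layer faster. Compound 1 gives 4.3 10^-6 cm/s, and compound 2 gives 14.5 10^-6 cm/s. The change from compound 1 to compound 2 is hydroxy in place of hydrogen on an aromatic carbon, and it made a 3.4-fold higher number from compound 1 to compound 2 (0.53 log units; beyond the scatter). Compound 3 differs from compound 1 by chloro in place of hydrogen on an aromatic carbon, and that step was a 1.7-fold lower number from compound 1 to compound 3 (0.22 log units; within the scatter). Compound 3 gives 2.6 10^-6 cm/s.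

Compound 4, `Oc1ccc2cc(-c3cc(Cl)c(O)c4ncccc34)oc2c1`, has not yet been run in this assay. It differs from compound 3 by hydroxy in place of hydrogen on an aromatic carbon, the same kind of change as that from compound 1 to compound 2, though the place is not identical: in compound 2 the hydroxy sits ortho to a fused ring and meta to a fused ring, while in compound 4 it sits meta to a fused ring and para to a fused ring. Resting on the step of a 3.4-fold higher number from compound 1 to compound 2 (0.53 log units; beyond the scatter), the step for compound 4 is expected to be about a 3.4-fold higher number from compound 3 to compound 4 (0.53 log units; beyond the scatter). Compound 4 is therefore estimated at 8.8 10^-6 cm/s, with a likely range from 4 10^-6 cm/s to 18 10^-6 cm/s.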

Compound 4, apparent permeability: 17.9 10^-6 cm/s
Estimate against measurement, compound 4: 2.0-fold (0.31 log units) below, and the stated range covers the measured number.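

In this assay, hydroxy in place of hydrogen on an aromatic carbon again gave a rise, with a 6.9-fold higher number from compound 3 to compound 4 (0.84 log units; beyond the scatter). The step on the chloro-bearing core of compound 3 points the same way as the earlier step on the core of compound 1, and the two agree as far as the scatter can tell: the same change on two cores in this assay, a 3.4-fold higher number (0.53 log units; beyond the scatter) from compound 1 to compound 2 and a 6.9-fold higher number (0.84 log units; beyond the scatter) from compound 3 to compound 4, 2.0-fold (0.31 log units) apart, within the scatter of two such steps. For the compounds shown here, these are only two pairs, however, and the hydroxy stands in a different place in each, so they do not amount to a rule for the series, cannot separate the influence of the core from that of the place, and give no reason for the size of either step.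

A compound carrying chloro together with the hydroxy in the place it has in compound 2 would test the core on its own. On these data alone, it also remains open whether an amine, a carboxylic acid or a methoxy group in place of that hydrogen would move the number in the same way.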